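The compounds below may be only part of what the source reports. "The series", "measured", "known", "first", "only" and "open" are said of these compounds alone.

Measured in a functional assay on the whole organism for antagonist activity, with Rattus norvegicus as the target; on this read-out higher numbers stand for an effect only at larger amounts of compound and lower numbers for an effect already at smaller amounts:
- Compound 1 `CN(C)C1CCN(C(=O)CCCOc2cc(C(=O)N3CCCCc4sccc43)ccc2NC(=O)c2ccccc2-c2ccccc2)CC1`: 0.005 mg/kg
- Compound 2 `CN1CCN(C(=O)CCCOc2cc(C(=O)N3CCCCc4sccc43)ccc2NC(=O)c2ccccc2-c2ccccc2)CC1`: 0.03 mg/kg
- Compound 3 `CN1CCCN(CCCOc2cc(C(=O)N3CCCCc4sccc43)ccc2NC(=O)c2ccccc2-c2ccccc2)CC1`: 0.03 mg/kg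

Compound 3 stands level with compound 2 at the digits shown, and together they hold the highest of the three numbers. Compound 4 `CN1CCCN(C(=O)CCCOc2cc(C(=O)N3CCCCc4sccc43)ccc2NC(=O)c2ccccc2-c2ccccc2)CC1` differs from compound 3 by (4-methyl-1,4-diazepan-1-yl)carbonyl in place of 4-methyl-1,4-diazepan-1-yl on a saturated chain carbon, three bonds along the chain from an oxygen on an aromatic ring, on a saturated chain carbon, three bonds along the chain from an oxygen on an aromatic ring. The closest evidence is no change at the digits printed from compound 2 to compound 3 (within the scatter), which joins a carbonyl-bearing compound to one without that carbonyl. The amine on the carbonyl can still matter, as a 6.0-fold higher number from compound 1 to compound 2 (0.78 log units; beyond the scatter) shows. No step beyond the scatter is therefore expected in this assay. The estimated change is a 1.5-fold lower number from compound 3 to compound 4 (0.18 log units; within the scatter). Compound 4 is expected at 0.02 mg/kg, with an estimated range of 0.006 mg/kg to 0.06 mg/kg.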

Compound 4, dose for 50% inhibition: 0.008 mg/kg
Compound 4: the middle estimate sits 2.5-fold (0.40 log units) above what was measured; the range from low to high includes it.
By their numbers in this assay, from the lowest: compounds 1 and 4 (each within the scatter of the next); then compounds 2 and 3 (each within the scatter of the next).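

In this assay adding the carbonyl to the 4-methyl-1,4-diazepan-1-yl group gives a 3.8-fold lower number from compound 3 to compound 4 (0.57 log units; beyond the scatter) and so shows that the carbonyl counts at this saturated chain carbon, which the comparison of compound 2 and compound 3 could not separate from the change of ring. On the carbonyl carbon, 4-methyl-1,4-diazepan-1-yl in place of 4-methylpiperazin-1-yl gives a 3.8-fold lower number from compound 2 to compound 4 (0.57 log units; beyond the scatter) while the same group in place of 4-(dimethylamino)piperidin-1-yl gives a 1.6-fold higher number from compound 1 to compound 4 (0.20 log units; within the scatter) and thus stays within the scatter. No measurement here explains these steps.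

Still open, as far as these compounds go, is whether removing the carbonyl has the same effect with 4-(dimethylamino)piperidin-1-yl as the amine. From the compounds shown here alone, how a morpholine on the carbonyl or a longer chain would read also remains open.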